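Replacing a Furanylmethylamino Group on a Nucleoside Core

The source may hold more compounds than are shown below. What is called first, only, known or untested is meant among the compounds shown, and "the series" means these compounds.

Compound 1 `OC[C@H]1O[C@@H](n2cnc3c(NCc4ccco4)ncnc32)[C@H](O)[C@@H]1O` is one of two compounds tested in an assay on isolated protein for binding affinity to Equilibrative nucleoside transporter 1 (Homo sapiens); a higher number here means a weaker inhibitor, a lower number a stronger inhibitor. There compound 1 gives 36300 nM, the lower of the two numbers. The other, compound 2 `CCCn1cnc2c(SC(C)C)nc(N)nc21`, gives in this assay 145000 nM, a gap that lies beyond the usual scatter. The next compound, compound 3 `OC[C@H]1O[C@@H](n2cnc3c(CSc4ccc(I)cc4)ncnc32)[C@H](O)[C@@H]1O`, keeps the core of compound 1 and changes one group: a group of 9 heavy atoms (7 carbon, 1 sulfur, 1 iodine; one six-membered aromatic ring of carbon only) in place of a group of 7 heavy atoms (5 carbon, 1 nitrogen, 1 oxygen; one five-membered aromatic ring with 1 hetero atom), on an aromatic carbon. Within the data shown here, no measured pair shows the effect of such a change, so the expectation rests on compound 1 alone. The step of a 12-fold lower number from compound 1 to compound 3 (1.08 log units; beyond the scatter) is expected to be a sizeable drop in the number. In this assay compound 3 is therefore estimated at 3000 nM, in a range from 300 nM to 30000 nM.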

Compound 3, half-maximal inhibitory concentration: 69.2 nM
Compound 3: middle estimate off by 43-fold (1.64 log units), on the high side; the whole stated range lies above it.
By their numbers in this assay, from the lowest: compound 3; then compound 1; then compound 2.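

In this assay, a group with a six-membered carbon aromatic ring, sulfur and iodine replaces ((furan-2-yl)methyl)amino on the aromatic carbon opposite the ring nitrogen, giving a 520-fold lower number from compound 1 to compound 3 (2.72 log units; beyond the scatter). A change at this one position of the shared core can therefore move the number by a large step. No measurement available here accounts for the size of this step.

From the compounds shown here alone, the step changes the ring, the heteroatoms and the hydrogen-bond donor count together, so which of these matters remains open. Going by these compounds, whether bromine in place of the iodine, or oxygen in place of the sulfur, would keep the number this low also remains open.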